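Adding a methyl to the core of compound 3

This account rests on a few compounds, and the source may have more. Where it says the series, first, only, none or still open, it means among the compounds named here.

Values in a functional assay on cells (Leukemia cell, Homo sapiens) for inhibition (a lower number here means a stronger inhibitor of growth, a higher number a weaker inhibitor of growth), follow
- Compound 1 `Cc1cc(-c2nc3sc(C)cn3c2/C=N/NC(=N)N)c(C)s1` gives 47900 nM
- Compound 2 `Cc1cn2c(/C=N/NC(=N)N)c(-c3ccsc3)nc2s1` gives 7760 nM
- Compound 3 `N=C(N)N/N=C/c1c(-c2cccs2)nc2sccn12` gives 6760 nM

Compound 3 and compound 2 lie within the scatter of each other, and both sit well under compound 1. Compound 4 `Cc1cn2c(/C=N/NC(=N)N)c(-c3cccs3)nc2s1` differs from compound 3 in one place: methyl in place of hydrogen on an aromatic carbon, next to the ring sulfur (methyl in place of hydrogen on an aromatic carbon). Within the data shown here, the only measured step (a 6.2-fold lower number from compound 1 to compound 2 (0.79 log units; beyond the scatter)) changes the thiophene group, not this carbon, so it bears on the question only loosely. Compound 2 already carries this methyl and gives (7760 nM), close to compound 3. No change beyond the scatter is therefore expected in this assay, and the expected step is small (a 1.0-fold higher number from compound 3 to compound 4 (0.02 log units; within the scatter)). The estimate for compound 4 is (7000 nM), with an expected range from 2800 nM to 18000 nM.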

Compound 4, concentration for 50% growth inhibition: 1820 nM
The estimate for compound 4 lay 3.8-fold (0.59 log units) above the measured number, and the stated range ends above it.
By their numbers in this assay, from the lowest: compound 4; then compounds 3 and 2 (each within the scatter of the next); then compound 1.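

In this assay, the methyl on this aromatic carbon, next to the ring sulfur, has a real effect on the number when the thiophen-2-yl group is present (a 3.7-fold lower number from compound 3 to compound 4 (0.57 log units; beyond the scatter)). With the methyl held in place, the thiophene group also matters: thiophen-2-yl outperforms thiophen-3-yl (a 4.3-fold lower number from compound 2 to compound 4 (0.63 log units; beyond the scatter)) and 2,5-dimethylthiophen-3-yl (a 26-fold lower number from compound 1 to compound 4 (1.42 log units; beyond the scatter)). Nothing available explains why either change lowers the number. Going by these compounds, it remains open whether the methyl gives a similar step alongside thiophen-3-yl. Whether an ethyl, an amine or a carboxylic acid on this carbon would match the methyl is also unknown.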